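The compounds below may be only part of what the source reports. "The series", "measured", "known", "first", "only" and "open" are said of these compounds alone.

Values in an ADME assay on Vero cells (Chlorocebus sabaeus) for cytotoxicity, with a stated time of 5 days; on this read-out lower numbers stand for stronger inhibition and higher numbers for weaker inhibition (the sign marks a limit of the assay, not a number):
- Compound 1 `CC(C)(CO)Nc1nc(N)nc2c1ncn2[C@H]1C[C@H](N=[N+]=[N-])[C@@H](CO)O1` gives > 100000 nM
- Compound 2 `[N-]=[N+]=N[C@H]1C[C@H](n2cnc3c(Cl)nc(F)nc32)O[C@@H]1CO` gives 21800 nM
- Compound 3 `[N-]=[N+]=N[C@H]1C[C@H](n2cnc3c(N)nc(Cl)nc32)O[C@@H]1CO` gives > 100000 nM

Compound 1 stands at the limit of > 100000 nM in this assay, at which 2 of the 3 values shown sit, and so has only a limit, not an exact number. For the measured compounds named here, compound 4 `[N-]=[N+]=N[C@H]1C[C@H](n2cnc3c(NCCO)nc(N)nc32)O[C@@H]1CO` shares the core of compound 1 but carries 2-hydroxyethyl in place of 1-(hydroxymethyl)-1-methylethyl on a nitrogen on an aromatic ring as its single change. Going by the values given here, no measured pair shows this swap, so any forecast is rough. In this assay no step beyond the usual scatter is expected, and the estimated a number no higher from compound 1 to compound 4 (the limit leaves the size open) is correspondingly small. Compound 4 is estimated at 100000 nM with an expected range from 40000 nM to 200000 nM and may well return only a limit.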

Compound 4, half-maximal inhibitory concentration: > 100000 nM
Compound 4: only a limit was reported (the forecaster's own chance of this, stated with the estimate: 75%); the middle value sits exactly at the limit.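

Compound 1 and compound 4 both stop at the same limit, so no step between them can be read: the limit of > 100000 nM in this assay, at which 3 of the 4 values shown sit.

The compounds shown leave open whether 2-hydroxyethyl in place of 1-(hydroxymethyl)-1-methylethyl changes the value at all.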